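The compounds below may be only part of what the source reports. "The series", "measured", "known", "first", "only" and "open" are said of these compounds alone.

In an ADME assay on the whole organism (Mus musculus, strain CD1) for pharmacokinetics, read by LC-MS, with a stated time of 24 h, at a dose of 5 mg/kg by the oral route (on this read-out higher numbers stand for higher oral bioavailability and lower numbers for lower oral bioavailability), compound 1 (`O=C(O)Cn1nc(Cc2cn3cc(OCC4CC4)c(Cl)cc3n2)c2ccccc2c1=O`) gives 5%, compound 3 (`O=C(O)Cc1nn(Cc2cn3cc(OCC4CC4)c(Cl)cc3n2)c2ccccc2c1=O`) gives 14% and compound 2 (`O=C(O)Cn1nc(Cn2cc3cc(OCC4CC4)c(Cl)cc3n2)c2ccccc2c1=O`) gives 19%. Compound 2 and compound 3 lie within the scatter of each other, while compound 2 stands above compound 1 by more than the scatter. Compound 4 (`C[C@H](C(=O)O)n1nc(Cn2cc3cc(OCC4CC4)c(Cl)cc3n2)c2ccccc2c1=O`) departs from compound 2 by methyl in place of hydrogen on a saturated chain carbon bound to an aromatic nitrogen and a carbonyl carbon. Going by the values given here, no measured pair shows this change, so the expectation starts from compound 2 at 19%. The estimated step of a number 5 percentage points higher from compound 2 to compound 4 (within the scatter) is a small rise in this assay, not expected to pass the scatter. For compound 4 the expected value is 24%, with an estimated range from 9% to 45%.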

Compound 4, oral bioavailability: 60%
The estimate for compound 4 lay 36 percentage points below the measured number, and the stated range ends below it.
By their numbers in this assay, from the lowest: compounds 1, 3 and 2 (each within the scatter of the next, the first and the last beyond it); then compound 4.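

In this assay, the change from carboxymethyl to 1-carboxyethyl gives a number 41 percentage points higher from compound 2 to compound 4 (beyond the scatter), so one added methyl on a saturated chain carbon bound to an aromatic nitrogen and a carbonyl carbon carries a large step. Going by these compounds alone, none of the earlier compounds bears anything but hydrogen on its acid chain carbon, so they could not show this. Nothing at hand bears on what lies behind the step. On these data alone, it remains open whether an ethyl group or a longer chain at this place would give a similar step. As far as these compounds go, whether the same methyl would act likewise on the core of compound 1 or compound 3 also stays open.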